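Two Dimethoxyphenyl Isomers at an Assay Limit

This account rests on a few compounds, and the source may have more. Where it says the series, first, only, none or still open, it means among the compounds named here.

Compound 1 `CN(C)c1ccc(C=C2C(=O)N(c3ccc(Cl)cc3)N(c3ccc(Cl)cc3)C2=O)cc1` and compound 2 `COc1ccc(C=C2C(=O)N(c3ccc(Cl)cc3)N(c3ccc(Cl)cc3)C2=O)cc1OC` share one core and were both tested in a functional assay on SMMC-7721 cells (Homo sapiens) for cytotoxicity, read by MTT assay, with a stated time of 72 h; a lower number here means a stronger inhibitor, a higher number a weaker inhibitor. Compound 1 gives > 128000 nM, which is a limit of the assay and not a number. Compound 2 gives > 128000 nM, which is likewise a limit. The record so far therefore amounts to the limit of > 128000 nM in this assay, at which 2 of the 2 values shown sit. Among the measured compounds shown here, the one measured step is a step that the two limits leave unreadable from compound 1 to compound 2, so it offers no size to carry forward.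

Compound 3 `COc1cccc(C=C2C(=O)N(c3ccc(Cl)cc3)N(c3ccc(Cl)cc3)C2=O)c1OC` keeps the same core and differs from compound 2 in one place: 2,3-dimethoxyphenyl in place of 3,4-dimethoxyphenyl on a double-bonded chain carbon bound to a double-bonded ring carbon. Here 2,3-dimethoxyphenyl stands in place of 3,4-dimethoxyphenyl on a double-bonded chain carbon bound to a double-bonded ring carbon, and the two compounds have the same atoms, joined differently.

With only compound 2 and its limit > 128000 nM as a starting point, no step beyond the scatter is expected in this assay, and another limit is the likeliest report. The estimated step is a number no higher from compound 2 to compound 3 (the limit leaves the size open). Compound 3 is estimated at 128000 nM, with an expected range from 64000 nM to 256000 nM.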

Compound 3, half-maximal inhibitory concentration: 14100 nM
Estimate against measurement, compound 3: 9.1-fold (0.96 log units) above; measured number outside the range, below it.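

In this assay, among the compounds shown here, putting 2,3-dimethoxyphenyl in place of 3,4-dimethoxyphenyl on a double-bonded chain carbon bound to a double-bonded ring carbon gives the first step of readable size at this position (an at least 9.0-fold lower number from compound 2 to compound 3 (0.95 log units; beyond the scatter)). The group that leaves and the group that enters match in heavy atoms, hydrogen-bond donors, hydrogen-bond acceptors and charge, so the two differ only in how their atoms are joined, and that difference alone takes the number away from the limit. The same group set against 4-(dimethylamino)phenyl gives a step beyond the scatter as well (an at least 9.0-fold lower number from compound 1 to compound 3 (0.95 log units; beyond the scatter)), while the step between the two earlier compounds cannot be read, and the limit still holds most of the record: the limit of > 128000 nM in this assay, at which 2 of the 3 values shown sit.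

On these data alone, the true size of both readable steps stays open, as each is bounded on one side only. The compounds shown also leave open whether a hydroxyl group or a fluorine atom in place of either methoxy group of compound 3 would keep the number clear of the limit.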